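The source may hold more compounds than are shown below. What is called first, only, known or untested is meant among the compounds shown, and "the series" means these compounds.

In a functional assay on the whole organism for inhibition, with Rattus norvegicus as the target, read by paw edema, with a stated time of 1 h, at a dose of 50 mg/kg (a lower number here means less inhibition, a higher number more inhibition at the dose given (going by the name of the read-out)), compound 2 `Cc1ccc(-n2nc3cc(C)oc(=O)c3c2C)cc1` gives 63.3%. For the measured compounds named here, the only other compound measured, compound 1 `Cc1cc2nn(-c3ccccc3)c(C)c2c(=O)o1`, gives 57% in this assay, and the step of a number 6.3 percentage points higher from compound 1 to compound 2 (within the scatter) lies within the scatter, so compound 2 stands level with compound 1 rather than apart from it. Compound 3 `Cc1cc2nn(-c3ccc(Cl)cc3)c(C)c2c(=O)o1` has not yet been measured in this assay. It differs from compound 2 in one place: chloro in place of methyl on an aromatic carbon.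

Going by the values given here, only one measured step bears on this change, and only loosely: the step of a number 6.3 percentage points higher from compound 1 to compound 2 (within the scatter), which put a methyl in place of hydrogen on an aromatic carbon, and which stayed within the scatter. Among the compounds with values here, no measured step shows chloro in place of methyl, so there is nothing to point to a shift in either direction. The step from compound 2 to compound 3 in this assay is therefore expected to be a number 3.3 percentage points lower from compound 2 to compound 3 (within the scatter), nothing beyond the scatter. Compound 3 is accordingly estimated at 60% in this assay, with a range from 45% to 75%.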

Compound 3, a percentage reported as inhibition, in the whole organism at one dose (the size of the read-out at that dose, not a potency): 58.2%
Compound 3: the middle estimate sits 1.8 percentage points above what was measured; the range from low to high includes it.
By their numbers in this assay, from the lowest: compounds 1, 3 and 2 (each within the scatter of the next).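

In this assay, chloro in place of methyl on an aromatic carbon, para to a large group, gives a number 5.1 percentage points lower from compound 2 to compound 3 (within the scatter) and stays level with the methyl compound, while chloro in place of hydrogen at that same place gives a number 1.2 percentage points higher from compound 1 to compound 3 (within the scatter) and stays level with the unsubstituted compound as well. The earlier pair had shown only hydrogen and methyl at this position; with chloro added, three different occupants now stand within the scatter of one another, so none of the three sets a compound apart at this dose and time. No measurement among those given speaks to why these three compounds stand level.

Going by these compounds, whether a group of another kind on this aromatic carbon, such as an amine, a carboxylic acid or a longer chain, would give a step beyond the scatter stays open. The compounds shown also leave open whether chloro or methyl would behave the same way at another place on this ring, and whether the three would remain level at another dose or time.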